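Compound 3 to compound 4: a hydroxymethyl step

This account rests on a few compounds, and the source may have more. Where it says the series, first, only, none or still open, it means among the compounds named here.

In an ADME assay on HEK293 cells (Homo sapiens) for cytotoxicity, with a stated time of 6 h (on this read-out higher numbers stand for lower toxicity in this test and lower numbers for higher toxicity in this test), compound 1 (`CCCCNc1nc(N)nc2cccc(OC)c12`) gives > 25000 nM, which is a limit. Going by the values given here, compound 2 (`CCCCNc1nc(N)nc2cccc(OCc3ccccc3)c12`) gives 10000 nM, the only actual number so far. Compound 3 (`CCCCNc1nc(N)nc2cccc(OCc3ccccc3OC)c12`) gives > 25000 nM, also a limit, so it stands at the limit of > 25000 nM in this assay, at which 2 of the 3 values shown sit.

Two steps can be read: an at least 2.5-fold lower number from compound 1 to compound 2 (0.39 log units; beyond the scatter), and an at least 2.5-fold higher number from compound 2 to compound 3 (0.39 log units; beyond the scatter). Among the compounds with values here, the second is the closest precedent, also replacing hydrogen on an aromatic carbon, though with methoxy.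

Compound 4 (`CCCCNc1nc(N)nc2cccc(OCc3ccc(CO)cc3OC)c12`) follows from compound 3 through (hydroxymethyl in place of hydrogen on an aromatic carbon). Within the data shown here, no measured step tests hydroxymethyl, so no change beyond the scatter is expected, and a further limit is likely. The expected step is a step that the limit leaves unreadable from compound 3 to compound 4. The estimate for compound 4 is 28000 nM, with an expected range of 12000 nM to 60000 nM.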

Compound 4, half-maximal cytotoxic concentration: 16000 nM
Compound 4: the middle estimate sits 1.8-fold (0.24 log units) above what was measured, within the range that was stated.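

In this assay, hydroxymethyl in place of hydrogen, para to a large group and meta to a methoxy group, gives an at least 1.5-fold lower number from compound 3 to compound 4 (0.19 log units; that floor lies within the scatter) as the only change at this carbon among the compounds shown. The value of compound 3, > 25000 nM here, is a limit. The real size of the step cannot be read, because its starting point is such a limit: the limit of > 25000 nM in this assay, at which 2 of the 4 values shown sit.

From the compounds shown here alone, whether an aminomethyl group or a carboxylic acid on this carbon would shift the number in this assay stays open. Also open, going by these compounds, is what hydroxymethyl does on a ring without the methoxy group.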